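Swapping oxygen for sulfur on a shared diamine core

The source may report more compounds than this note shows. Statements on the series, on what has been measured and on what is new or still open speak of the compounds shown alone.

For the measured compounds named here, compound 3 `Nc1cc(N)c2nc(-c3ccccc3)c(Oc3ccc(F)cc3)nc2c1` carries a 4-fluorophenoxy group, and in a functional assay on OVCAR-8 cells (Homo sapiens) for inhibition, read by sulforhodamine B assay, with a stated time of 48 h (a lower number here means that less compound is tolerated, a higher number that more compound is tolerated), compound 3 gives 100000 nM, the only plain number among the three values shown. Compound 1 `COc1ccc(Sc2nc3cc(N)cc(N)c3nc2-c2ccccc2)cc1` reaches only a limit of this assay, < 100000 nM. Compound 2 `Nc1cc(N)c2nc(-c3ccccc3)c(Sc3ccc(Cl)c(Cl)c3)nc2c1` likewise stops at a limit, < 100000 nM. Compound 4 `Nc1cc(N)c2nc(-c3ccccc3)c(Sc3ccc(F)cc3)nc2c1` differs from compound 3 by (4-fluorophenyl)sulfanyl in place of 4-fluorophenoxy on an aromatic carbon. The measured steps of a number no lower from compound 1 to compound 3 (the limit leaves the size open) and a number no lower from compound 2 to compound 3 (the limit leaves the size open), as well as the step between the two limits a step that the two limits leave unreadable from compound 1 to compound 2, all rest on the limit of < 100000 nM in this assay, at which 2 of the 3 values shown sit, and leave no readable size or direction. With nothing readable to lean on, compound 4 is expected near 100000 nM, between 30000 nM and 300000 nM. The step of no change at the digits printed from compound 3 to compound 4 (within the scatter) is therefore estimated to stay within the usual scatter.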

Compound 4, concentration lethal to 50% of the cells: 72400 nM
For compound 4 the middle estimate is 1.4-fold (0.14 log units) above the measured one; the range from low to high includes it.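

For the compounds shown here, the change from 4-fluorophenoxy to (4-fluorophenyl)sulfanyl gives the first step of readable size at this position, a 1.4-fold lower number from compound 3 to compound 4 (0.14 log units; within the scatter) in this assay. With the 4-fluorophenyl ring kept the same, oxygen and sulfur as the linking atom cannot be told apart in this read-out. The steps from compound 1 and compound 2 to compound 4 cannot be read, because they rest on a limit: the limit of < 100000 nM in this assay, at which 2 of the 4 values shown sit.

Going by these compounds, what an amine linking the same 4-fluorophenyl ring to this aromatic carbon would give stays open.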